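The source may hold more compounds than are shown below. What is called first, only, known or untested is meant among the compounds shown, and "the series" means these compounds.

Measured compounds:

- compound 1, `O=C(c1cc(-c2ccc(Cl)cc2)n(-c2ccc(=O)[nH]n2)n1)N1CCCCC1`: 2090 nM
- compound 2, `O=C(c1cc(-c2ccc(Cl)cc2)n(-c2ccc(=O)[nH]n2)n1)N1CCOCC1`: 12600 nM
- compound 3, `COc1ccc(-n2nc(CCC(=O)N3CCCCC3)cc2-c2ccc(Cl)cc2)nn1`: 920 nM

All three were run in a functional assay on a cell-free system (Platelet, plasma, Homo sapiens) for inhibition, read by turbidimetry, with a stated time of 3 min; on this read-out higher numbers stand for weaker inhibition and lower numbers for stronger inhibition. Compound 3 gives the lowest number of the three; compound 1 stands nearest to it and compound 2 furthest, both steps beyond the scatter. How the core of compound 3 differs from the core of compound 1 is not broken down here.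

One change is made twice in the set. From compound 1 to compound 2 it reads (morpholin-4-yl in place of piperidin-1-yl on a carbonyl carbon), and it gave a 6.0-fold higher number from compound 1 to compound 2 (0.78 log units; beyond the scatter). The same kind of change carries compound 3 to compound 4, `COc1ccc(-n2nc(CCC(=O)N3CCOCC3)cc2-c2ccc(Cl)cc2)nn1`, not yet measured: morpholin-4-yl in place of piperidin-1-yl on a carbonyl carbon. The two places are not the same word for word: in compound 1 the carbonyl carbon has an aromatic carbon as its other neighbour, in compound 3 a saturated chain carbon, so the change is of the same kind rather than the same.

For the measured compounds named here, with only one earlier instance to go on, the expectation for compound 4 is a step of about the same size and direction, a 6.0-fold higher number from compound 3 to compound 4 (0.78 log units; beyond the scatter), because the change from compound 1 to compound 2 gave a 6.0-fold higher number from compound 1 to compound 2 (0.78 log units; beyond the scatter). Compound 4 is therefore expected at roughly 5500 nM in this assay, with a range from 2000 nM to 15000 nM allowed for the difference in what sits next to the carbonyl carbon.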

Compound 4, half-maximal inhibitory concentration: 1080 nM
The estimate for compound 4 lay 5.1-fold (0.71 log units) above the measured number; the whole stated range lies above it.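

In this assay, morpholin-4-yl in place of piperidin-1-yl on a carbonyl carbon whose other neighbour is a saturated chain carbon gives a 1.2-fold higher number from compound 3 to compound 4 (0.07 log units; within the scatter), so on this core the swap leaves the read-out unresolved. Set beside the same kind of change on the core of compound 1, the step does not carry over in size: the same change on two cores in this assay, a 6.0-fold higher number (0.78 log units; beyond the scatter) from compound 1 to compound 2 and a 1.2-fold higher number (0.07 log units; within the scatter) from compound 3 to compound 4, 5.1-fold (0.71 log units) apart, beyond the scatter of two such steps. For the compounds shown here, this shows that the penalty seen on the core of compound 1 cannot be assumed for another core, but it does not show which difference between the cores decides the outcome, as those cores differ in more than one place and only two instances of the change are at hand, too few to support a rule for either kind of core.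

The compounds shown leave open whether other amine parts on the carbonyl carbon, such as piperazin-1-yl or an open-chain dimethylamino group, would follow compound 3 and compound 4 or compound 1 and compound 2. They also leave open how the same swap behaves on a longer chain, or on a shorter one of a single methylene, between the carbonyl carbon and the shared core of compound 3 and compound 4.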